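The source may hold more compounds than are shown below. What is called first, only, known or untested is meant among the compounds shown, and "the series" means these compounds.

Working notes on the series: two ureas measured so far, compound 1 `C[C@H](NC(=O)Nc1ccccc1F)c1ccccc1` and compound 2 `Cc1ccc(NC(=O)N[C@H](C)c2ccccc2)c(F)c1`. In an ADME assay on the whole organism with Oryza sativa as the target, tested at 1 uM (on this read-out lower numbers stand for a stronger effect and higher numbers for a weaker effect at the one concentration tested), compound 1 gives 92%, and compound 2 gives 99%; of the two numbers that of compound 2 is the upper one, yet compound 1 sits within the usual scatter of it, so the pair shows no real difference. Compound 3 `Cc1ccc(NC(=O)N[C@@H](C)c2ccccc2)c(F)c1` awaits measurement and differs from compound 2 as follows: the two compounds have the same atoms and bonds and differ only in configuration as drawn: 1 of 1 stereo elements differ; a stereocentre at a saturated chain carbon is drawn R in compound 2 and S in compound 3. Among the compounds with values here, no step between measured compounds is available to guide the size. In this assay the expected step is a number 5 percentage points lower from compound 2 to compound 3 (within the scatter), no direction beyond the scatter. Compound 3 is therefore estimated at 94%, between 80% and 100%.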

Compound 3, a percentage reported as activity, at one concentration (the size of the read-out at that concentration, not a potency): 99%
Estimate against measurement, compound 3: 5 percentage points below; the measured number falls inside the stated range.
By their numbers in this assay, from the lowest: compounds 1, 2 and 3 (each within the scatter of the next).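

Within the data shown here, with the stereocentre at the saturated chain carbon inverted, this assay gives no change at the digits printed from compound 2 to compound 3 (within the scatter), the first reading of configuration alone, and it shows no separation between the two forms. This pair isolates that one change: the fact that compounds 2 and 3 differ only in the configuration as drawn. Methyl in place of hydrogen on an aromatic carbon can now also be read as a single change, giving a number 7 percentage points higher from compound 1 to compound 3 (within the scatter), so neither change moves the number beyond the scatter. From the compounds shown here alone, it remains open whether a carboxylic acid or an amine on the aromatic ring, or a longer chain at the stereocentre, would do so.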